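Swapping the Amide Aryl Group: Tert-Butyl Out, Dichloro In

A few compounds are considered here, and "the series" means these few. Any claim that something is new, unique, unknown or untested is made for them only; others in the source may bear on it.

Three anilides on a shared core have been tested in a functional assay on MCF7 cells (Homo sapiens) for inhibition, read by MTT assay; a higher number here means a weaker inhibitor, a lower number a stronger inhibitor. Compound 1 `COc1cc2ncnc(Nc3ccc(NC(=O)c4ccc(C)cc4)cc3)c2cc1OC` carries a 4-methylphenyl on a carbonyl carbon and gives 19000 nM. Compound 3 `COc1cc2ncnc(Nc3ccc(NC(=O)c4c(F)cccc4F)cc3)c2cc1OC`, with 2,6-difluorophenyl on that carbonyl carbon, gives 24000 nM, and a 1.3-fold higher number from compound 1 to compound 3 (0.10 log units; within the scatter). Compound 2 `COc1cc2ncnc(Nc3ccc(NC(=O)c4ccc(C(C)(C)C)cc4)cc3)c2cc1OC` is reported only as a limit of the assay, > 100000 nM, which is the limit of > 100000 nM in this assay, at which 1 of the 3 values shown sits. Accordingly an at least 5.2-fold higher number from compound 1 to compound 2 (0.72 log units; beyond the scatter), and an at least 4.1-fold lower number from compound 2 to compound 3 (0.61 log units; beyond the scatter).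

Compound 4 `COc1cc2ncnc(Nc3ccc(NC(=O)c4ccc(Cl)c(Cl)c4)cc3)c2cc1OC` has not yet been measured. It differs from compound 2 in one place: 3,4-dichlorophenyl in place of 4-(tert-butyl)phenyl on a carbonyl carbon. Among the compounds with values here, two measured steps bear on this exchange, since each of them either introduces or removes the 4-(tert-butyl)phenyl. The introduction, an at least 5.2-fold higher number from compound 1 to compound 2 (0.72 log units; beyond the scatter), and the removal, an at least 4.1-fold lower number from compound 2 to compound 3 (0.61 log units; beyond the scatter), were both at least modest. A 3,4-dichlorophenyl replacing the 4-(tert-butyl)phenyl is therefore expected to bring the number back down into the region occupied by compounds 1 and 3. The expected step is an at least 4.0-fold lower number from compound 2 to compound 4 (0.60 log units; beyond the scatter). For compound 4 the estimated value in this assay is 25000 nM, with a range from 8000 nM to 80000 nM.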

Compound 4, half-maximal inhibitory concentration: 25000 nM
Estimate against measurement, compound 4: no gap at the digits printed, and the stated range covers the measured number.
By their numbers in this assay, from the lowest: compounds 1, 3 and 4 (each within the scatter of the next). At a limit, above all of these: compound 2.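

In this assay, exchanging the 4-(tert-butyl)phenyl for 3,4-dichlorophenyl on the carbonyl carbon gives an at least 4.0-fold lower number from compound 2 to compound 4 (0.60 log units; beyond the scatter), so this exchange, like the two measured before it, moves the number away from compound 2. The dichlorinated group also does not separate from either of the other two aryl groups, with a 1.0-fold higher number from compound 3 to compound 4 (0.02 log units; within the scatter) and a 1.3-fold higher number from compound 1 to compound 4 (0.12 log units; within the scatter). Among the four compounds, therefore, methyl, two fluorines and two chlorines on the aryl ring all give numbers within the scatter of one another, and compound 2, with its 4-(tert-butyl)phenyl, is the one that goes against this grouping.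

On these data alone, compound 2 is reported only as a limit, so the full size of every step from it remains unknown: the limit of > 100000 nM in this assay, at which 1 of the 4 values shown sits. Also open is whether an amine, a carboxylic acid or a longer chain on the aryl ring would stay with compounds 1, 3 and 4 in this assay, join compound 2 at the limit, or give a number beyond the scatter on the stronger side of all of them.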